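A few compounds are considered here, and "the series" means these few. Any claim that something is new, unique, unknown or untested is made for them only; others in the source may bear on it.

Measured so far in a functional assay on PANC-1 cells (Homo sapiens) for inhibition, read by MTT assay, with a stated time of 24 h; on this read-out higher numbers stand for weaker inhibition and lower numbers for stronger inhibition:

- Compound 1 `COc1ccccc1NC(=O)Oc1cc(=O)n(CCCO)c2c1CC(CC=C(C)C)C(C)(C)C2`: 7700 nM
- Compound 2 `CC(C)=CCC1Cc2c(OC(=O)Nc3ccc(F)cc3)cc(=O)n(CCCO)c2CC1(C)C`: 7700 nM
- Compound 3 `CC(C)=CCC1Cc2c(OC(=O)Nc3ccc(F)c(F)c3)cc(=O)n(CCCO)c2CC1(C)C`: 7300 nM

Compound 2 gives 7700 nM, level with compound 1, and all three numbers lie within the scatter of one another. Compound 4 `CC(C)=CCC1Cc2c(OC(=O)Nc3ccc(F)c(Cl)c3)cc(=O)n(CCCO)c2CC1(C)C` keeps everything in compound 2 except for one change on the aromatic ring of the carbamate: chloro in place of hydrogen on an aromatic carbon. In words, this is chloro in place of hydrogen on an aromatic carbon, ortho to a fluoro group.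

The closest measured change puts fluoro in place of hydrogen on an aromatic carbon, and it gives a 1.1-fold lower number from compound 2 to compound 3 (0.02 log units; within the scatter). Two larger swaps of the aromatic group also bear on this: no change at the digits printed from compound 1 to compound 2 (within the scatter) and a 1.1-fold lower number from compound 1 to compound 3 (0.02 log units; within the scatter). Within the data shown here, no chloro compound has been measured yet, so this is an extrapolation. Since every aromatic change so far stayed within the scatter, no step beyond the scatter is expected in this assay. The estimated step is a 1.1-fold lower number from compound 2 to compound 4 (0.03 log units; within the scatter). For compound 4 the expected value is 7200 nM, with an estimated range from 4200 nM to 11500 nM.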

Compound 4, half-maximal inhibitory concentration: 6800 nM
Compound 4: the middle estimate sits 1.1-fold (0.02 log units) above what was measured; low and high end bracket the measured number.
By their numbers in this assay, from the lowest: compounds 4, 3, 1 and 2 (each within the scatter of the next).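

Chloro appears here for the first time, on the aromatic ring and ortho to a fluoro group, and in this assay adding it leaves the result within the scatter (a 1.1-fold lower number from compound 2 to compound 4 (0.05 log units; within the scatter)). Chloro and fluoro at this place cannot be told apart either (a 1.1-fold lower number from compound 3 to compound 4 (0.03 log units; within the scatter)). Even the full exchange of 2-methoxyphenyl for 3-chloro-4-fluorophenyl stays within the scatter (a 1.1-fold lower number from compound 1 to compound 4 (0.05 log units; within the scatter)), so among these compounds, hydrogen, fluoro and chloro at this place give no readable difference.

Nothing available gives a reason for this flat result. As far as these compounds go, it remains open whether an amine, a carboxylic acid or a longer chain at this place would give a step beyond the scatter, and what changes elsewhere on the shared core would do.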